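A Pyridine Isomer Exchanged on the Amine Nitrogen

The source may hold more compounds than are shown below. What is called first, only, known or untested is meant among the compounds shown, and "the series" means these compounds.

Compound 2 `C[C@@H](Cn1ccc(-c2ccc(C#N)c(Cl)c2)n1)Nc1cccnc1` is the only one of the two measured compounds that gives a number in a functional assay on LNCaP cells (Homo sapiens) for antiproliferative activity, read by CCK-8 assay, with a stated time of 6 days; on this read-out lower numbers stand for stronger inhibition and higher numbers for weaker inhibition: compound 2 gives 430 nM. Compound 1 `C[C@@H](Cn1ccc(-c2ccc(C#N)c(Cl)c2)n1)NS(=O)(=O)c1cn(C)cn1` stands at a limit of the assay rather than at a number; in this assay compound 1 gives > 30000 nM. Going by the values given here, the single measured step, an at least 69-fold lower number from compound 1 to compound 2 (1.84 log units; beyond the scatter), rests on that limit of > 30000 nM in this assay, at which 1 of the 2 values shown sits, and so gives only a floor for its size.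

Compound 3 `C[C@@H](Cn1ccc(-c2ccc(C#N)c(Cl)c2)n1)Nc1ccccn1` differs from compound 2 by pyridin-2-yl in place of pyridin-3-yl on an amine nitrogen. The two structures have the same atoms, joined differently. Among the compounds with values here, no measured step bears directly on this kind of change: the step from compound 1 to compound 2 exchanged a sulfonyl group for a pyridyl ring, whereas the change to compound 3 keeps the pyridyl ring and only alters how it is joined. With nothing pointing one way or the other, he expects no step beyond the scatter, a 1.4-fold higher number from compound 2 to compound 3 (0.14 log units; within the scatter). His estimate for compound 3 in this assay is therefore 600 nM, within a range from 150 nM to 3000 nM.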

Compound 3, half-maximal inhibitory concentration: 1110 nM
Estimate against measurement, compound 3: 1.9-fold (0.27 log units) below; the range from low to high includes it.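

The result shows that at this amine nitrogen, in this assay, the number depends not only on having a pyridyl ring but also on how that ring is joined: with the same atoms, the exchange gives a 2.6-fold higher number from compound 2 to compound 3 (0.41 log units; beyond the scatter). Going by these compounds alone, the earlier pair showed only that a pyridyl ring could take the place of a whole sulfonyl group, and it could not tell whether one pyridyl isomer would serve as well as another. The modest gap between the two isomers is small beside the larger step, an at least 27-fold lower number from compound 1 to compound 3 (1.43 log units; beyond the scatter), and that larger step gives only a floor for its size, as it rests on a limit of the assay: the limit of > 30000 nM in this assay, at which 1 of the 3 values shown sits.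

The compounds shown leave open where pyridin-4-yl on the same nitrogen would fall relative to pyridin-3-yl and pyridin-2-yl, and whether a plain phenyl ring, with no ring nitrogen, would match either isomer. They also give no reason for the gap between compound 2 and compound 3, and they do not show whether that gap would persist with a methyl group on the amine nitrogen.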